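Replacing 4-Methylpiperazin-1-yl with (Pyridin-3-yl)oxy: An Expectation

The source may hold more compounds than are shown below. What is called first, only, known or untested is meant among the compounds shown, and "the series" means these compounds.

Measured so far:
Compound 1 `COc1ccc(-c2cc(=O)c3c(OC)cc(OC)cc3n2S(=O)(=O)c2ccc(OC)cc2)cc1` gives > 82700 nM in a functional assay on KOPN-8 cells (Homo sapiens) for antiproliferative activity, with a stated time of 72 h; a lower number here means that less compound is needed, a higher number that more compound is needed for the effect; this is a limit of the assay, not a number.
Compound 2 `COc1cc(OC)c2c(=O)cc(C(=O)Nc3ccc(N4CCN(C)CC4)cc3)[nH]c2c1` gives > 19800 nM in this assay; this too is a limit of the assay, not a number.

Among the measured compounds shown here, compound 2 therefore stands at a limit (the limit of > 19800 nM in this assay, at which 1 of the 2 values shown sits), and the only other value shown, that of compound 1, is also a limit (the limit of > 82700 nM in this assay, at which 1 of the 2 values shown sits). For the measured compounds named here, no step between two measured compounds can be drawn from this, so nothing is known about how any single change moves the read-out.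

Compound 3 `COc1cc(OC)c2c(=O)cc(C(=O)Nc3ccc(Oc4cccnc4)cc3)[nH]c2c1` differs from compound 2 in one place: (pyridin-3-yl)oxy in place of 4-methylpiperazin-1-yl on an aromatic carbon. With compound 2 sitting at a limit, the step to compound 3 in this assay cannot be sized from data; the expectation is a step of no clear direction, within or near the usual scatter, with a real chance that compound 3 also returns only a limit. The estimated step is a step that the limit leaves unreadable from compound 2 to compound 3. Compound 3 is thus expected at 25000 nM, somewhere between 5000 nM and 100000 nM.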

Compound 3, half-maximal effective concentration: > 32100 nM
Compound 3 was reported as a limit; the forecaster's own chance of this, stated with the estimate: 65%; middle value at least 1.2-fold (0.10 log units) from the limit.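

Among the compounds shown here, compound 2 and compound 3 both return only limits in this assay, not numbers, and no step between them can be read. The compounds shown leave open how far, if at all, (pyridin-3-yl)oxy in place of 4-methylpiperazin-1-yl moves the read-out, and whether any compound of this series gives a measurable value in this assay.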